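The compounds below may be only part of what the source reports. "The series", "measured", "known", "first", "only" and "open" are said of these compounds alone.

Compound 1 `CCCCCNc1nc(Nc2ccc([N+](=O)[O-])cc2)nc(OCC(F)(F)F)n1` gives 74% in an ADME assay on microsomes from liver (Homo sapiens) for metabolic stability, with a stated time of 10 min; on this read-out lower numbers stand for a less stable compound and higher numbers for a more stable compound. Compound 2 `CC(C)(C)NC(=O)NCCS(=O)(=O)NC(=O)c1ccc(Nc2nc(NC3(c4ccc(Cl)cc4)CC3)nc(OCC(F)(F)F)n2)cc1` gives 96%. Compound 3 `CC(C)(C)OC(=O)NCCS(=O)(=O)NC(=O)c1ccc(Nc2nc(NC3(c4ccc(Cl)cc4)CC3)nc(OCC(F)(F)F)n2)cc1` gives 92%.

Among these three numbers compound 3 has the second highest. Its nearest neighbour is compound 2, and the step of a number 4 percentage points lower from compound 2 to compound 3 (within the scatter) lies within the scatter, so the two cannot be told apart on this read-out. Compound 1 stands furthest away; its number is lower than that of compound 3 by a gap beyond the scatter, but the two differ in several places at once, so only the two values themselves can be compared.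

The next compound, compound 4 `O=C(NS(=O)(=O)CCNC(=O)C1CC1)c1ccc(Nc2nc(NC3(c4ccc(Cl)cc4)CC3)nc(OCC(F)(F)F)n2)cc1`, has not yet been measured in this assay. It differs from compound 3 in one place: cyclopropyl in place of tert-butoxy on a carbonyl carbon. Among the compounds with values here, the only measured step that touches this same position is the one from compound 2 to compound 3, where the group on that carbonyl carbon was also exchanged and the number moved by a number 4 percentage points lower from compound 2 to compound 3 (within the scatter), within the scatter. A second exchange at the same carbonyl carbon is therefore expected to leave the read-out close to where compound 3 stands, with no step beyond the scatter in either direction. Compound 4 is thus estimated at 90%, with a range from 78% to 98%. The expected step is a number 2 percentage points lower from compound 3 to compound 4 (within the scatter).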

Compound 4, percent of the compound remaining: 90%
Compound 4: middle estimate and measured number agree at the digits printed; the measured number falls inside the stated range.
By their numbers in this assay, from the lowest: compound 1; then compounds 4, 3 and 2 (each within the scatter of the next).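

Within the data shown here, the reading is a number 2 percentage points lower from compound 3 to compound 4 (within the scatter) for cyclopropyl in place of tert-butoxy, and a number 6 percentage points lower from compound 2 to compound 4 (within the scatter) for cyclopropyl in place of (tert-butyl)amino, so no step at this carbonyl carbon yet rises above the scatter. Among these compounds, until now this position had been seen only with two open-chain groups, and cyclopropyl adds a different kind of group, with a three-membered ring, fewer heavy atoms than tert-butoxy and no hydrogen-bond acceptor, yet this assay still cannot tell the three compounds apart. Within these three compounds, then, the read-out shows no sensitivity to which of these groups sits on the carbonyl carbon, and nothing measured here offers an explanation for this.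

The compounds shown leave open whether a group of another kind on this carbonyl carbon, such as an amine-bearing chain, a carboxylic acid or a longer carbon chain, would also stay within the scatter or would produce a clear step. They also leave open whether these three groups would still read alike if the compounds stayed with the microsomes for longer.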